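Hydrogen for hydroxymethyl at the edge of the assay range

The source may hold more compounds than are shown below. What is called first, only, known or untested is meant among the compounds shown, and "the series" means these compounds.

Measured in a functional assay on K562 cells (Homo sapiens) for cytotoxicity, with a stated time of 72 h; a lower number here means a stronger inhibitor, a higher number a weaker inhibitor:
- Compound 1 `Cc1cccc(-c2nn3c(c2-c2ccncc2)C(CO)C(C)(C)C3)n1`: > 100000 nM (a limit)
- Compound 2 `CC1(C)Cc2c(-c3ccncc3)c(-c3ccccc3C#N)nn2C1`: > 100000 nM (a limit)
- Compound 3 `Cc1cccc(-c2nn3c(c2-c2ccncc2)C(C)C(C)(C)C3)c1C#N`: 92000 nM

Compound 1 stands at the limit of > 100000 nM in this assay, at which 2 of the 3 values shown sit. Its entry is a limit and not a number, and the same holds for compound 2. Only compound 3 gives a number in this assay.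

Compound 4 `Cc1cccc(-c2nn3c(c2-c2ccncc2)CC(C)(C)C3)n1` has not yet been measured. Its difference from compound 1 is counted as hydrogen in place of hydroxymethyl on a saturated ring carbon. Going by the values given here, no two measured compounds differ in one place, so the data give no direct size for this change. The expectation is therefore for no step beyond the scatter in this assay, with no direction favoured. Among the compounds with values here, the only number available as a guide comes from compound 3, at 92000 nM, and it points to compound 4 also lying at the edge of the measurable range. The estimated change is a number no higher from compound 1 to compound 4 (the limit leaves the size open). Compound 4 is estimated at 100000 nM, with an expected range from 40000 nM to 150000 nM, and a report as a limit is the likelier outcome.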

Compound 4, half-maximal inhibitory concentration: > 100000 nM
Compound 4 gave a limit, no number; the forecaster's own chance of this, stated with the estimate: 65%; the middle value sits exactly at the limit.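

In this assay compound 4 gives > 100000 nM, which is a limit and not a number. Compound 1 and compound 2 also stand at limits, so neither step to compound 4 can be read: the limit of > 100000 nM in this assay, at which 3 of the 4 values shown sit.

The compounds shown leave open the size and direction of hydrogen in place of hydroxymethyl on a saturated ring carbon, and of 6-methylpyridin-2-yl in place of 2-cyanophenyl on an aromatic carbon, in this assay.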